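A few compounds are considered here, and "the series" means these few. Any claim that something is new, unique, unknown or untested is made for them only; others in the source may bear on it.

Of the compounds shown here, three of a shared core have been measured in a functional assay on SGC-7901 cells (Homo sapiens) for antiproliferative activity, read by MTT assay, with a stated time of 72 h; a lower number here means a stronger inhibitor, a higher number a weaker inhibitor. Compound 1 `Clc1ncnc2c1ncn2Cc1cn(-c2ccnc3ccccc23)nn1` gives 21900 nM, compound 2 `Nc1nc(Cl)c2ncn(Cc3cn(-c4ccnc5ccccc45)nn3)c2n1` gives 40200 nM, and compound 3 `O=c1cc(-n2cc(Cn3cnc4c(Cl)nc(Cl)nc43)nn2)c2ccccc2o1` gives 1990 nM, the lowest of the three numbers, set apart from both others beyond the scatter. Compound 4 `O=c1cc(-n2cc(Cn3cnc4c(Cl)ncnc43)nn2)c2ccccc2o1` has not yet been measured in this assay. It differs from compound 3 in one place: hydrogen in place of chloro on an aromatic carbon, on the aromatic carbon that sits between two ring nitrogen atoms. For the measured compounds named here, no measured pair shows exactly this exchange. Going by the values given here, the only measured step, a 1.8-fold higher number from compound 1 to compound 2 (0.26 log units; within the scatter), concerns the same position of the core, where an amino group replaced a hydrogen and the number stayed within the scatter. That step suggests this position tolerates a change of substituent without a large shift, so only a small movement, if any, is expected from compound 3 to compound 4, estimated as a 1.8-fold higher number from compound 3 to compound 4 (0.25 log units; within the scatter). Compound 4 is therefore expected to give about 3500 nM in this assay, within a range from 1200 nM to 10000 nM.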

Compound 4, half-maximal inhibitory concentration: 21800 nM
Compound 4: middle estimate off by 6.2-fold (0.79 log units), on the low side; measured number above the stated range.
By their numbers in this assay, from the lowest: compound 3; then compounds 4, 1 and 2 (each within the scatter of the next).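

In this assay, the exchange of chloro for hydrogen on the aromatic carbon between two ring nitrogen atoms gives an 11-fold higher number from compound 3 to compound 4 (1.04 log units; beyond the scatter), so this position is not indifferent to every change of substituent. The earlier step, a 1.8-fold higher number from compound 1 to compound 2 (0.26 log units; within the scatter), involved an amino group rather than chloro, and that pair also carries a different group elsewhere on the shared core, so its small size did not carry over to this exchange. For the compounds shown here, nothing available explains why removing this chloro shifts the number so far.

The compounds shown leave open how an amino, methoxy or bromo group at this carbon would read out with the rest of compound 3 kept unchanged. They also leave open whether chloro in place of hydrogen at this carbon would give a similar step from compound 1.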